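The source may hold more compounds than are shown below. What is called first, only, known or untested is meant among the compounds shown, and "the series" means these compounds.

Compound 1 `CCn1c(SCC(=O)Nc2ccc(/C(C)=N/O)cc2)nnc1-c1ccc(OC)cc1` is the starting point of this account. In a functional assay on the whole organism (strain albino) for inhibition, with Rattus norvegicus as the target, read by paw edema, with stated times of 30 min and 3 h, at a dose of 0.28 mmol/kg by the oral route (on this read-out lower numbers stand for less inhibition and higher numbers for more inhibition at the one dose given (going by the name of the read-out)), compound 1 gives 60%. Compound 3 `C=CCn1c(SCC(=O)Nc2ccc(/C(C)=N/O)cc2)nnc1-c1ccc(OC)cc1` carries vinyl in place of methyl on a saturated chain carbon bound to an aromatic nitrogen, and in this assay compound 3 gives 63%; the step of a number 3 percentage points higher from compound 1 to compound 3 (within the scatter) is reported as within the scatter. Compound 2 `C=CCn1c(SCC(=O)Nc2ccc(/C(C)=N/O)cc2)nnc1-c1ccc(OC)c(OC)c1` differs from compound 3 by one group: hydrogen in place of methoxy on an aromatic carbon. In this assay compound 2 gives 70%, and the step of a number 7 percentage points lower from compound 2 to compound 3 (within the scatter) is likewise within the scatter. How the cores of compound 1 and compound 2 differ is not broken down here; their two values lie within the scatter of each other.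

Compound 4 `CCn1c(SCC(=O)Nc2ccc(/C(C)=N/O)cc2)nnc1-c1ccccc1` has not yet been measured. It differs from compound 1 in this way: hydrogen in place of methoxy on an aromatic carbon. Among the compounds with values here, the change is of the same kind as the one from compound 2 to compound 3, but not the same: in compound 2 the leaving group sits ortho to a methoxy group and meta to a large group, whereas in compound 1 it sits para to a large group. The expected step of a number 6 percentage points lower from compound 1 to compound 4 (within the scatter) rests on the earlier step of a number 7 percentage points lower from compound 2 to compound 3 (within the scatter), which stayed within the scatter, so a small drop is estimated. For compound 4 in this assay the expected value is 54%, estimated to fall between 40% and 68%.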

Compound 4, a percentage reported as inhibition, in the whole organism at one dose (the size of the read-out at that dose, not a potency): 65%
Beside the measured number, compound 4's estimate is 11 percentage points below it; measured number inside the range.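

Replacing 4-methoxyphenyl with phenyl on the core of compound 1 gives a number 5 percentage points higher from compound 1 to compound 4 (within the scatter) in this assay, so the loss of this methoxy group, para to a large group, leaves no change that can be told from the scatter. Set beside the earlier case of a methoxy group giving way to hydrogen on another core, the two steps do not differ: the same change on two cores in this assay, a number 7 percentage points lower (within the scatter) from compound 2 to compound 3 and a number 5 percentage points higher (within the scatter) from compound 1 to compound 4, 12 percentage points apart, within the scatter of two such steps. This shows that, across these two cores, the change carries over without a detectable difference in this read-out, but it does not show that the change has no effect on other cores, and with both steps inside the scatter, neither can be read as a real gain or loss, nor can a small core dependence be ruled out.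

The compounds shown hold only hydrogen or methoxy on this aromatic ring, so what a chlorine atom, a hydroxyl group or an amine would do there remains open. Equally open is how a longer chain such as butyl on the aromatic nitrogen would read, and how any of these compounds would behave at other doses, since only one dose is given.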